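Methyl to trifluoromethyl: working notes on compound 3

The source may hold more compounds than are shown below. What is called first, only, known or untested is meant among the compounds shown, and "the series" means these compounds.

Measured in a functional assay on MCF7 cells (Homo sapiens) for antiproliferative activity, read by MTT assay, with a stated time of 72 h; a lower number here means a stronger inhibitor, a higher number a weaker inhibitor:
- compound 1 `CC1=CC[C@H]2[C@H](CC[C@]2(C)O)C(C)(C)[C@@H]1CC[C@H]1[C@]2(C)CC[C@H](OC(=O)c3ccc(C)cc3)C(C)(C)O[C@H]2CC[C@@]1(C)O`: > 50000 nM
- compound 2 `CC1=CC[C@H]2[C@H](CC[C@]2(C)O)C(C)(C)[C@@H]1CC[C@H]1[C@]2(C)CC/C(=N/OCc3ccccc3)C(C)(C)O[C@H]2CC[C@@]1(C)O`: > 50000 nM

In this assay compound 1 stands at > 50000 nM, which is a limit of the assay and not a number. Compound 2 gives > 50000 nM, which is also a limit. Among the compounds with values here, the series so far therefore reads as follows: the limit of > 50000 nM in this assay, at which 2 of the 2 values shown sit. Within the data shown here, no order between the two compounds can be stated, and no measured step is available.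

Compound 3 `CC1=CC[C@H]2[C@H](CC[C@]2(C)O)C(C)(C)[C@@H]1CC[C@H]1[C@]2(C)CC[C@H](OC(=O)c3ccc(C(F)(F)F)cc3)C(C)(C)O[C@H]2CC[C@@]1(C)O` departs from compound 1 in one place: trifluoromethyl in place of methyl on an aromatic carbon. This puts trifluoromethyl in place of methyl on an aromatic carbon, para to a large group, and the core of compound 1 stays as it is. Among the measured compounds shown here, nothing measured so far shows what this replacement does.

The expectation rests only on compound 1 at > 50000 nM, a limit. The expected step in this assay is a number no higher from compound 1 to compound 3 (the limit leaves the size open), with no move beyond the scatter in either direction. For compound 3 the estimated value is 50000 nM, with an expected range of 20000 nM to 100000 nM.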

Compound 3, half-maximal inhibitory concentration: 23400 nM
Estimate against measurement, compound 3: 2.1-fold (0.33 log units) above; measured number inside the range.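

In this assay, within the data shown here, trifluoromethyl in place of methyl on an aromatic carbon, para to a large group, gives an at least 2.1-fold lower number from compound 1 to compound 3 (0.32 log units; beyond the scatter), the first measured step and the first indication that this position, on the (4-methylphenyl)carbonyl group of compound 1, responds to a change while the core stays as it is. The value of compound 1, > 50000 nM, is a limit of the assay and not a number. Compound 3 is the only compound shown that carries a number and not a limit, so it gives the series its first fixed point: the limit of > 50000 nM in this assay, at which 2 of the 3 values shown sit.

The compounds shown leave open whether this step is specific to trifluoromethyl or whether other replacements of methyl at the same place would read the same way, and a chlorine atom, a nitrile or a methoxy group on that aromatic carbon would test this. Also open, going by these compounds, is the true size of the step, and whether the same replacement would move a number on any other group attached to the shared core.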